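A few compounds are considered here, and "the series" means these few. Any claim that something is new, unique, unknown or untested is made for them only; others in the source may bear on it.

Within the data shown here, compound 1, with the structure `CCCCCCCC/C=C\CCCCCCCC(=O)N[C@H]1[C@@H](OCCCCCCCC)O[C@H](CO)[C@@H](O)[C@@H]1O`, is the stronger of the two compounds measured so far in a functional assay on A-375 cells (Homo sapiens), read by thymidine incorporation (on this read-out higher numbers stand for weaker inhibition and lower numbers for stronger inhibition), where compound 1 gives 6 uM. Its companion, compound 2, with the structure `CCCCCCCC/C=C\CCCCCCCC(=O)N[C@H]1[C@@H](OCCCCCCCC)O[C@H](COCC(CO)(CO)CO)[C@@H](O)[C@@H]1O`, gives 13.3 uM in this assay, and the step of a 2.2-fold higher number from compound 1 to compound 2 (0.35 log units; beyond the scatter) shows what happens when a large polyol is attached at a hydroxyl of compound 1. Compound 3, with the structure `CCCCCCCC/C=C\CCCCCCCC(=O)N[C@H]1[C@@H](OCCCCCCCC)O[C@H](CO)[C@@H](O)[C@@H]1OS(=O)(=O)O`, has not been measured. It differs from compound 1 by a change at a different hydroxyl: sulfo in place of hydrogen on an oxygen on a saturated carbon. Among the measured compounds shown here, the only measured step available for comparison is the one from compound 1 to compound 2, where a hydrogen on an oxygen on a saturated carbon was likewise exchanged for a larger, oxygen-rich group, and the number rose modestly. On that basis a small rise in this assay is expected for compound 3 as well, so that the estimated step of a 1.7-fold higher number from compound 1 to compound 3 (0.22 log units; within the scatter) points the same way. Compound 3 is therefore expected to give about 10 uM, with a likely range from 3 uM to 30 uM.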

Compound 3, concentration for 50% inhibition: 16 uM
For compound 3 the middle estimate is 1.6-fold (0.20 log units) below the measured one; the measured number falls inside the stated range.
By their numbers in this assay, from the lowest: compound 1; then compounds 2 and 3 (each within the scatter of the next).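

Placing sulfo on this oxygen, which sits on a saturated carbon whose other neighbours are saturated ring carbons, gives a 2.7-fold higher number from compound 1 to compound 3 (0.43 log units; beyond the scatter) in this assay, so this hydroxyl of compound 1 is also a place where a change shifts the read-out towards weaker inhibition. Among these compounds, until now, only the change at a different hydroxyl, the one leading to compound 2, had been seen to do that, so compound 1 now stays the lowest against changes at two separate oxygens, with both steps beyond the scatter. The shift is modest, and compound 3 still gives a finite number, 16 uM, so the swap from hydroxy to sulfooxy weakens inhibition without removing it, though nothing here explains the size of this shift.

On these data alone, with only sulfo at this oxygen, it remains open whether a small group such as methyl or acetyl, or a carboxylic acid carried on a short chain, would move the number as far. As far as these compounds go, it is also open whether sulfo at the other hydroxyls of the shared core would give a similar step.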